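The compounds below may be only part of what the source reports. "The series", "measured", "known", "first", "only" and "open" are said of these compounds alone.

Compound 1 `O=S1(=O)c2ccccc2CN1c1cc(F)cc(Oc2cccnc2)c1`: in a functional assay on Flp-In T-REx293 cells for antagonist activity at Free fatty acid receptor 1 (Homo sapiens), read by calcium flux (on this read-out lower numbers stand for stronger inhibition and higher numbers for weaker inhibition), compound 1 gives > 100000 nM, a limit of the assay rather than a number.
Compound 2 `Cc1ccccc1Oc1cc(F)cc(N2Cc3ccccc3S2(=O)=O)c1`: in this assay compound 2 gives 44700 nM.
Compound 3 `N#Cc1ccccc1Oc1cc(F)cc(N2Cc3ccccc3S2(=O)=O)c1`: in this assay compound 3 gives > 100000 nM, again only a limit.

Compound 3 therefore sits at the edge of what this assay can report, as the limit of > 100000 nM in this assay, at which 2 of the 3 values shown sit, records. Compound 4 `O=S1(=O)c2ccccc2CN1c1cc(F)cc(Oc2ccncc2)c1` differs from it by pyridin-4-yl in place of 2-cyanophenyl on an oxygen on an aromatic ring. Of the measured steps, a step that the two limits leave unreadable from compound 1 to compound 3 is the closest relative, and an at least 2.2-fold lower number from compound 1 to compound 2 (0.34 log units; beyond the scatter) and an at least 2.2-fold higher number from compound 2 to compound 3 (0.34 log units; beyond the scatter) show the methyl analogue alone moving off the limit. Compound 1, which carries the pyridin-3-yl, sits at the limit > 100000 nM. The expected step that the limit leaves unreadable from compound 3 to compound 4 is accordingly none that the assay can read. Compound 4 is estimated at 150000 nM, within 60000 nM to 400000 nM.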

Compound 4, half-maximal inhibitory concentration: > 100000 nM
Compound 4: no number, only a limit (the forecaster's own chance of this, stated with the estimate: 85%); the middle value does not contradict the limit.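

In this assay compound 4 gives > 100000 nM, which is a limit of the assay and not a number. Going by these compounds alone, putting pyridin-4-yl in place of 2-methylphenyl gives an at least 2.2-fold higher number from compound 2 to compound 4 (0.34 log units; beyond the scatter), leaving compound 2 as the only compound here with a measured number: the limit of > 100000 nM in this assay, at which 3 of the 4 values shown sit. The steps to compound 4 from compound 1 and compound 3 have limits at both ends and cannot be read.

Going by these compounds, the true values past the limit remain unknown, so the pyridin-3-yl and pyridin-4-yl groups cannot be ranked. Also open, on these data alone, is whether an ethyl or methoxy group in place of the methyl of compound 2 would give a lower number.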